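The compounds below may be only part of what the source reports. "The series", "measured", "known", "first", "only" and "open" are said of these compounds alone.

Measured in a functional assay on MCF7 cells (Homo sapiens) for cytotoxicity, read by MTT assay, with a stated time of 48 h; on this read-out higher numbers stand for weaker inhibition and lower numbers for stronger inhibition:
compound 1 `CC(=O)Nc1ccc2nc(SCC(=O)NCc3ccccc3)sc2c1` — 17600 nM
compound 2 `O=C(CSc1nc2ccc(NC(=O)c3ccccc3)cc2s1)NCc1ccccc1` — 35600 nM
compound 3 `O=C(CSc1nc2ccc(NC(=O)CCl)cc2s1)NCc1ccccc1` — 4200 nM

Compound 1 stands second highest of the three numbers; the nearest is a 2.0-fold higher number from compound 1 to compound 2 (0.31 log units; beyond the scatter), the furthest is a 4.2-fold lower number from compound 1 to compound 3 (0.62 log units; beyond the scatter). Compound 4 `CNC(=O)CSc1nc2ccc(NC(C)=O)cc2s1` differs from compound 1 in one place: hydrogen in place of phenyl on a saturated chain carbon bound to an amide-type nitrogen. The measured steps all concern the carbonyl carbon on the other side of the shared core and do not touch the saturated chain carbon bound to the amide-type nitrogen, so none bears directly on this change. Among the compounds with values here, with no step to lean on, the removal of phenyl is expected to give a modest move toward a higher number in this assay, wider in uncertainty than the measured steps. Compound 4 is therefore expected at 30000 nM, within 9000 nM to 100000 nM, as a step of a 1.7-fold higher number from compound 1 to compound 4 (0.23 log units; within the scatter).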

Compound 4, half-maximal inhibitory concentration: > 100000 nM
Compound 4 gave a limit, no number; the forecaster's own chance of this, stated with the estimate: 25%; middle value at least 3.3-fold (0.52 log units) away from the limit.
By their numbers in this assay, from the lowest: compound 3; then compound 1; then compound 2. At a limit, above all of these: compound 4.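

In this assay compound 4 gives > 100000 nM, which is a limit of the assay and not a number. Hydrogen in place of phenyl on a saturated chain carbon bound to an amide-type nitrogen gives an at least 5.6-fold higher number from compound 1 to compound 4 (0.75 log units; beyond the scatter), so this end of the series also moves the number, not only the carbonyl carbon on the other side of the shared core. The full size of this step stays unknown: the limit of > 100000 nM in this assay, at which 1 of the 4 values shown sits.

Open, on these data alone, is whether an ethyl, a longer chain, or a phenyl carrying an amine or a carboxylic acid at this place would hold the number of compound 1. Also open, as far as these compounds go, is whether the chloromethyl of compound 3 would keep its number with hydrogen in place of phenyl here.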